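Hydrazone aryl swap in the benzyl quinoxaline series

The source may report more compounds than this note shows. Statements on the series, on what has been measured and on what is new or still open speak of the compounds shown alone.

Compound 1 `COc1ccc(/C=N/Nc2nc3ccccc3nc2Cc2ccccc2)cc1OC` gives the highest of the three numbers in an assay on isolated protein for inhibition of Amine oxidase [flavin-containing] B (Homo sapiens), read by spectrophotometry (a lower number here means a stronger inhibitor, a higher number a weaker inhibitor), at 460000 nM. Compound 2 `COc1cc(/C(C)=N/Nc2nc3ccccc3nc2Cc2ccccc2)cc(OC)c1OC` lies within the scatter of it with 260000 nM. Among the compounds with values here, compound 3 `Clc1ccc(/C=N/Nc2nc3ccccc3nc2Cc2ccccc2)cc1` gives 84000 nM, the one step beyond the scatter: a 5.5-fold lower number from compound 1 to compound 3 (0.74 log units; beyond the scatter). Compound 4 `Clc1ccccc1/C=N/Nc1nc2ccccc2nc1Cc1ccccc1` differs from compound 1 by 2-chlorophenyl in place of 3,4-dimethoxyphenyl on a carbon with a double bond to nitrogen. Within the data shown here, the only measured step that bears on this is the exchange of the same dimethoxyphenyl for a chlorophenyl, a 5.5-fold lower number from compound 1 to compound 3 (0.74 log units; beyond the scatter), which was modest. A comparable drop is therefore expected, though the chlorine now sits elsewhere on the ring, so the estimate is hedged: a 3.8-fold lower number from compound 1 to compound 4 (0.58 log units; beyond the scatter). For compound 4 in this assay the expected value is 120000 nM, with a range from 40000 nM to 350000 nM.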

Compound 4, half-maximal inhibitory concentration: 87000 nM
Estimate against measurement, compound 4: 1.4-fold (0.14 log units) above; low and high end bracket the measured number.
By their numbers in this assay, from the lowest: compounds 3 and 4 (each within the scatter of the next); then compounds 2 and 1 (each within the scatter of the next).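

In this assay, 2-chlorophenyl and 4-chlorophenyl cannot be told apart on this carbon: a 1.0-fold higher number from compound 3 to compound 4 (0.02 log units; within the scatter). The lower number relative to 3,4-dimethoxyphenyl therefore holds for both chlorophenyl groups, with a 5.3-fold lower number from compound 1 to compound 4 (0.72 log units; beyond the scatter) as a second step beyond the scatter. No available measurement explains these steps.

As far as these compounds go, it remains open whether an unsubstituted phenyl, a fluorophenyl or an aminophenyl on this carbon would match the chlorophenyl compounds. Also open, from the compounds shown here alone, is whether a single methoxy group would give a number nearer compound 1 or compound 3.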